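From a hydroxy-bearing group to 4-ethylphenyl

A few compounds are considered here, and "the series" means these few. Any claim that something is new, unique, unknown or untested is made for them only; others in the source may bear on it.

Measured so far in a functional assay on PC-3 cells (Homo sapiens) for inhibition, read by sulforhodamine B assay, with a stated time of 48 h; a higher number here means a weaker inhibitor of growth, a lower number a stronger inhibitor of growth
Compound 1 `Cc1ccc(C2=NN(c3ccc(S(C)(=O)=O)cc3)C(=O)CC2)cc1` gives 1430 nM
Compound 2 `Cc1cc(O)ccc1C1=NN(c2ccc(S(C)(=O)=O)cc2)C(=O)CC1` gives 14800 nM

Among the compounds with values here, of these two numbers, the one for compound 2 is the higher, so it is the weaker inhibitor of growth, and compound 1 is its nearest neighbour. The next compound to consider is compound 3 `CCc1ccc(C2=NN(c3ccc(S(C)(=O)=O)cc3)C(=O)CC2)cc1`, which differs from compound 2 in one place. The change is 4-ethylphenyl in place of 4-hydroxy-2-methylphenyl on a carbon with a double bond to nitrogen and, in words, 4-ethylphenyl comes in place of 4-hydroxy-2-methylphenyl on a carbon with a double bond to nitrogen.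

Within the data shown here, one measured step bears on this, namely a 10-fold higher number from compound 1 to compound 2 (1.01 log units; beyond the scatter), a large step in which 4-hydroxy-2-methylphenyl replaced 4-methylphenyl. Among the measured compounds shown here, compound 3 removes that same group again, but brings ethyl rather than methyl, and no measurement yet compares those two here. A step of similar size in the opposite direction is therefore expected in this assay, towards a lower number and a stronger inhibitor. The expected change is a 9.3-fold lower number from compound 2 to compound 3 (0.97 log units; beyond the scatter), close to undoing the earlier step. Compound 3 is estimated at 1600 nM, with an expected range from 500 nM to 5000 nM.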

Compound 3, concentration for 50% growth inhibition: 2760 nM
Compound 3: the middle estimate sits 1.7-fold (0.24 log units) below what was measured; the measured number falls inside the stated range.
By their numbers in this assay, from the lowest: compounds 1 and 3 (each within the scatter of the next); then compound 2.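

In this assay, the step of a 5.4-fold lower number from compound 2 to compound 3 (0.73 log units; beyond the scatter) shows that a lower number at this position does not depend on 4-methylphenyl alone, since 4-ethylphenyl, which has no hydroxy group, also gives one. The step of a 1.9-fold higher number from compound 1 to compound 3 (0.29 log units; within the scatter) lies within the scatter, so this assay does not separate methyl from ethyl on the ring, and the added carbon shows no measurable change here. Compound 2 is the only compound of the three with a hydroxy group, but its ring also carries the methyl of the 4-hydroxy-2-methylphenyl group, so the compounds shown cannot assign its higher number to the hydroxy group or to that methyl alone.

Nothing measured here accounts for any of these steps. Also open, on these data alone, is how far this position tolerates change, for example whether a longer chain such as propyl keeps the number in the same range, or whether an amine or a carboxylic acid on the ring in place of ethyl moves it as far as the 4-hydroxy-2-methylphenyl group does.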